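The compounds below may be only part of what the source reports. "The series", "measured", "known", "first", "only" and "open" are said of these compounds alone.

Compound 1 `CCc1ccc2[nH]c(=O)c(CN(Cc3ccc(F)cc3)Cc3ccc(C(C)(C)C)cc3)cc2c1`, compound 2 `CCc1ccc2[nH]c(=O)c(CN(CCCO)Cc3ccc(C(C)(C)C)cc3)cc2c1` and compound 3 `CCc1ccc2[nH]c(=O)c(CN(Cc3ccc(C(C)(C)C)cc3)C(C)c3ccc(OC)cc3)cc2c1` share one core and differ only in the groups carried on the amine nitrogen. In a toxicity assay on MDCK cells (Canis lupus familiaris) for cytotoxicity, read by crystal violet staining, with a stated time of 48 h (a higher number here means that more compound is tolerated, a lower number that less compound is tolerated), compound 1 gives only a limit, > 33000 nM. In this assay compound 2 likewise gives only a limit, > 10000 nM. Compound 3 also gives only a limit in this assay, > 5000 nM. The steps a step that the two limits leave unreadable from compound 1 to compound 2, a step that the two limits leave unreadable from compound 1 to compound 3 and a step that the two limits leave unreadable from compound 2 to compound 3 are all unreadable; each rests on limits, namely (the limit of > 10000 nM in this assay, at which 1 of the 3 values shown sits), the limit of > 33000 nM in this assay, at which 1 of the 3 values shown sits, and (the limit of > 5000 nM in this assay, at which 1 of the 3 values shown sits). Compound 4 `CCc1ccc2[nH]c(=O)c(CN(Cc3ccc(C(C)(C)C)cc3)[C@@H](C)c3ccc(OC)cc3)cc2c1` differs from compound 3 in one respect: the two compounds have the same atoms and bonds; at least one stereo element is drawn with a configuration in one of them and without one in the other: 1 of 1 stereo elements differ; a stereocentre at a saturated chain carbon is drawn without a configuration in compound 3 and S in compound 4. Within the data shown here, no measured step bears on this change with a readable size, so the expected step that the limit leaves unreadable from compound 3 to compound 4 lies within the scatter. Compound 4 is therefore expected to sit at 10000 nM in this assay, with a range from 3000 nM to 33000 nM.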

Compound 4, half-maximal cytotoxic concentration: > 5000 nM
Compound 4: only a limit was reported (the forecaster's own chance of this, stated with the estimate: 80%); the middle value does not contradict the limit.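

Among these compounds, compound 1, compound 2, compound 3 and compound 4 all give only limits in this assay, and no step to compound 4 can be read. As far as these compounds go, whether the S configuration or any amine nitrogen group changes the tolerated concentration stays open.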